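From a fluorinated to a methylated aryl ring

The source may hold more compounds than are shown below. What is called first, only, known or untested is meant among the compounds shown, and "the series" means these compounds.

Within the data shown here, compound 2 `O=[N+]([O-])c1ccc(N/C(=N\O)c2cccc(F)c2)c2nonc12` gives 75 nM in an assay on isolated protein for inhibition of Indoleamine 2,3-dioxygenase 1 (Homo sapiens), read by spectrophotometry, with a stated time of 1 h (a higher number here means a weaker inhibitor, a lower number a stronger inhibitor), the lowest of the two numbers measured so far. Among the measured compounds shown here, the only comparator is compound 1 `O=[N+]([O-])c1ccc(N/C(=N\O)c2ccccc2)c2nonc12`, which in this assay gives 268 nM; the step of a 3.6-fold lower number from compound 1 to compound 2 (0.55 log units; beyond the scatter) came from a fluoro in place of hydrogen on an aromatic carbon. Compound 3 `Cc1ccc(/C(=N/O)Nc2ccc([N+](=O)[O-])c3nonc23)cc1` has not been measured. It differs from compound 2 in one place: 4-methylphenyl in place of 3-fluorophenyl on a carbon with a double bond to nitrogen. For the measured compounds named here, the fluorine that accompanied the lower number of compound 2 is gone, and a methyl enters instead; the single measured step shows only that this ring accepts a small change, and no measurement shows how a methyl behaves here. A modest rise toward the number of compound 1 is therefore expected, a 2.7-fold higher number from compound 2 to compound 3 (0.43 log units; beyond the scatter), without leaving the span of the two measured values. The estimate for compound 3 is 200 nM, with a range from 70 nM to 600 nM.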

Compound 3, half-maximal inhibitory concentration: 204 nM
Estimate against measurement, compound 3: 1.0-fold (0.01 log units) below; measured number inside the range.
By their numbers in this assay, from the lowest: compound 2; then compounds 3 and 1 (each within the scatter of the next).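

Putting a methyl on the aromatic ring gives a 1.3-fold lower number from compound 1 to compound 3 (0.12 log units; within the scatter), so in this assay the 4-methylphenyl ring of compound 3 cannot be told apart from the unsubstituted ring of compound 1. Exchanging 3-fluorophenyl for 4-methylphenyl gives a 2.7-fold higher number from compound 2 to compound 3 (0.43 log units; beyond the scatter), which shows that not every small substituent on this ring behaves alike: among the three compounds, only compound 2 stands apart from the others. Nothing available explains this difference between the two rings.

The step between compound 2 and compound 3 changes both the group and its place on the ring, so the contribution of each remains unseparated. Going by these compounds, how a methoxy group, an amine or a carboxylic acid on this ring would behave also remains open.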